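Aryl methyl on the amide partner of a weak pair

The source may report more compounds than this note shows. Statements on the series, on what has been measured and on what is new or still open speak of the compounds shown alone.

The two measured compounds share a core carrying a long chain to the group at its end: compound 1 `Cc1ccc(-c2noc(CCCCCCC(=O)NO)n2)cc1` bears a hydroxamic acid and compound 2 `Nc1ccccc1NC(=O)CCCCCCc1nc(-c2ccccc2)no1` an amide of an aromatic diamine. In an assay on isolated protein for inhibition of histone deacetylase 8 (Homo sapiens), read by fluorescence, with a stated time of 10 min (a higher number here means a weaker inhibitor, a lower number a stronger inhibitor), compound 1 gives 5390 nM. For compound 2 this assay returns only a limit, > 10000 nM, which is not a number; compound 2 thus sits at the limit of > 10000 nM in this assay, at which 1 of the 2 values shown sits. Compound 3 `Cc1ccc(-c2noc(CCCCCCC(=O)Nc3ccccc3N)n2)cc1` differs from compound 2 by methyl in place of hydrogen on an aromatic carbon, in words methyl in place of hydrogen on an aromatic carbon. Among the measured compounds shown here, no measured pair isolates this change, so no step size is known from the data. Such a change is expected to shift this assay by no more than the usual scatter, and the step is estimated as a step that the limit leaves unreadable from compound 2 to compound 3. Compound 3 is accordingly expected near 15000 nM, within 6000 nM to 50000 nM, and most likely again reported only as a limit.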

Compound 3, half-maximal inhibitory concentration: 8390 nM
Estimate against measurement, compound 3: 1.8-fold (0.25 log units) above; measured number inside the range.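

In this assay compound 3 gives a readable number on the 4-methylphenyl core, whereas compound 2 stands at a limit of the assay, not a number: the limit of > 10000 nM in this assay, at which 1 of the 3 values shown sits.

As far as these compounds go, the change from phenyl to 4-methylphenyl therefore reads as an at least 1.1-fold lower number from compound 2 to compound 3 (0.07 log units; that floor lies within the scatter), a floor only, and the true size of this step stays unknown. With the 4-methylphenyl group held fixed, 2-aminophenyl in place of hydroxy on the amide-type nitrogen gives a 1.6-fold higher number from compound 1 to compound 3 (0.19 log units; within the scatter), so this assay does not separate the hydroxamic acid from the amide of the aromatic diamine in this pair.

Still open, from the compounds shown here alone, is whether a chlorine, a methoxy group or an amine at the same place on the ring would move the number beyond the scatter. Also open, going by these compounds, is how a shorter or longer chain would read with either end group.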